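This account rests on a few compounds, and the source may have more. Where it says the series, first, only, none or still open, it means among the compounds named here.

Compound 2 `CC(C(=O)N1CCC(C)(C)CC1)N1CCN(S(=O)(=O)c2ccc(C(C)(C)C)cc2)CC1` stands at a limit of the assay in an ADME assay on HepG2 cells (Homo sapiens) for inhibition, with a stated time of 48 h; on this read-out higher numbers stand for an effect only at larger amounts of compound and lower numbers for an effect already at smaller amounts: compound 2 gives > 40000 nM, a limit and not a number. Compound 1 `CC(C(=O)N1CCCCCC1)N1CCN(S(=O)(=O)c2ccc(C(C)(C)C)cc2)CC1` likewise reaches only a limit, giving > 40000 nM in this assay. The step that the two limits leave unreadable from compound 1 to compound 2 is therefore unreadable. Compound 3 `CC(C(=O)N1CCN(C)CC1)N1CCN(S(=O)(=O)c2ccc(C(C)(C)C)cc2)CC1` differs from compound 2 by 4-methylpiperazin-1-yl in place of 4,4-dimethylpiperidin-1-yl on a carbonyl carbon. No measured step can be read, because the limit of > 40000 nM in this assay, at which 2 of the 2 values shown sit, holds for every value shown. The step that the limit leaves unreadable from compound 2 to compound 3 is expected to remain unreadable. Compound 3 is thus expected to give 50000 nM, in a range from 20000 nM to 120000 nM, most likely again as a limit.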

Compound 3, half-maximal effective concentration: > 40000 nM
Compound 3 was reported as a limit; the forecaster's own chance of this, stated with the estimate: 80%; the middle value is on the limit's open side.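

Within the data shown here, no step among compound 1, compound 2 and compound 3 can be read in this assay, with all three reported only as a limit: the limit of > 40000 nM in this assay, at which 3 of the 3 values shown sit. The compounds shown leave open how these three amide groups rank, since none gives an actual number.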